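Working notes: from compound 2 to compound 4

The compounds below may be only part of what the source reports. "The series", "measured", "known", "first", "only" and "open" are said of these compounds alone.

In a functional assay on SPCA2 cells (Homo sapiens) for cytotoxicity, read by MTT assay, with a stated time of 2 days (a higher number here means a weaker inhibitor, a lower number a stronger inhibitor), compound 1 (`Cc1ccc(CO/N=C2/C(c3c[nH]c4ccc(F)cc34)=Nc3ccc(F)cc32)cc1`) gives 11000 nM, compound 2 (`Cc1ccc(CO/N=C2/C(c3c[nH]c4ccc(Br)cc34)=Nc3ccc(Br)cc32)cc1`) gives 15100 nM and compound 3 (`FC(F)(F)c1ccc(CO/N=C2/C(c3c[nH]c4ccccc34)=Nc3ccccc32)cc1`) gives 21200 nM. Compound 2 stands within the scatter of both others, so these numbers show no order. Compound 4 (`FC(F)(F)c1ccc(CO/N=C2/C(c3c[nH]c4ccc(Br)cc34)=Nc3ccc(Br)cc32)cc1`) carries trifluoromethyl in place of methyl on an aromatic carbon, para to a large group (trifluoromethyl in place of methyl on an aromatic carbon). Among the compounds with values here, no measured pair isolates this change. The expectation rests on compound 3, which holds trifluoromethyl at 21200 nM and stays within the scatter of compound 2, although the two differ in more than this group. In this assay no step beyond the scatter is expected, so no direction is claimed. The estimated step is a 1.1-fold higher number from compound 2 to compound 4 (0.03 log units; within the scatter) and stays within the scatter. Compound 4 is expected at 16000 nM (estimated range 8000 nM to 32000 nM).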

Compound 4, half-maximal inhibitory concentration: 12400 nM
Compound 4: middle estimate off by 1.3-fold (0.11 log units), on the high side; measured number inside the range.
By their numbers in this assay, from the lowest: compounds 1, 4, 2 and 3 (each within the scatter of the next).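

Within the data shown here, compounds 2 and 4 form the first pair that isolates trifluoromethyl in place of methyl on an aromatic carbon, para to a large group. In this assay, this change gives a 1.2-fold lower number from compound 2 to compound 4 (0.09 log units; within the scatter), so the two groups are not separated at this position on this core. Nothing available bears on a cause for this result.

On these data alone, whether an amine, a carboxylic acid or a longer chain at this position would give a step beyond the scatter remains open. Also open, as far as these compounds go, is whether the same change would read alike on the core of compound 1.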